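The source may hold more compounds than are shown below. What is called first, only, known or untested is meant among the compounds shown, and "the series" means these compounds.

Measured in a functional assay on A549 cells (Homo sapiens) for cytotoxicity, read by MTT assay, with a stated time of 48 h; a lower number here means a stronger inhibitor, a higher number a weaker inhibitor:
Compound 1 `Cc1ccc(S(=O)(=O)/N=C(/CCNC2=CC(=O)c3ccccc3C2=O)Nc2ccc(Cl)cc2)cc1` gives 29900 nM.
Compound 2 `Cc1ccc(S(=O)(=O)/N=C(/CCNC2=CC(=O)c3ccccc3C2=O)Nc2ccccc2[N+](=O)[O-])cc1` gives 5010 nM.

Compound 2 gives the lower of the two numbers, and the step of a 6.0-fold lower number from compound 1 to compound 2 (0.78 log units; beyond the scatter) lies beyond the scatter. Compound 3 `Cc1ccc(S(=O)(=O)/N=C(/CCNC2=CC(=O)c3ccccc3C2=O)Nc2ccccc2I)cc1` differs from compound 2 by iodo in place of nitro on an aromatic carbon. Within the data shown here, no measured step swaps nitro for iodo on this ring; the only step that bears on it, a 6.0-fold lower number from compound 1 to compound 2 (0.78 log units; beyond the scatter), replaced the whole aryl group and is therefore a loose guide. A modest move toward a higher number in this assay is expected, a 2.0-fold higher number from compound 2 to compound 3 (0.30 log units; within the scatter). Compound 3 is estimated to give 10000 nM, within 3000 nM to 35000 nM.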

Compound 3, half-maximal inhibitory concentration: 24700 nM
Beside the measured number, compound 3's estimate is 2.5-fold (0.39 log units) below it; the range from low to high includes it.
By their numbers in this assay, from the lowest: compound 2; then compounds 3 and 1 (each within the scatter of the next).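

In this assay, iodo in place of nitro on the same aromatic carbon gives a 4.9-fold higher number from compound 2 to compound 3 (0.69 log units; beyond the scatter), so the lower number of compound 2 goes with the nitro group and not merely with a group at this place. The change from 4-chlorophenyl to 2-iodophenyl gives a 1.2-fold lower number from compound 1 to compound 3 (0.08 log units; within the scatter), which leaves those two compounds level. No evidence at hand accounts for the difference between nitro and iodo. As far as these compounds go, whether an amine, a nitrile or a methoxy group at this place would give a number nearer compound 2 or compound 3 stays open. So does whether nitro would hold its number at another carbon of the ring.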